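Difluoromethoxy in place of methoxy on a shared core

The source may hold more compounds than are shown below. What is called first, only, known or untested is meant among the compounds shown, and "the series" means these compounds.

For the measured compounds named here, compound 2 `COc1ccc2[nH]c(S(=O)(=O)Cc3ccc(OCc4nccc(OC)c4OC)c(OC)c3)nc2c1` is one of two compounds measured in a functional assay on cells (Erythrocyte, Homo sapiens); on this read-out higher numbers stand for weaker inhibition and lower numbers for stronger inhibition. In this assay compound 2 gives 898 nM, the lower of the two numbers shown, though the gap to compound 1 `COc1cc(CS(=O)(=O)c2nc3cc(OC(F)F)ccc3[nH]2)ccc1OCc1ncc(C)c(OC)c1C`, which gives 1420 nM, lies within the usual scatter. Compound 3 `COc1cc(CS(=O)(=O)c2nc3cc(OC(F)F)ccc3[nH]2)ccc1OCc1nccc(OC)c1OC` is not yet measured and differs from compound 2 by difluoromethyl in place of methyl on an oxygen on an aromatic ring. Going by the values given here, no measured pair isolates this change. Because compound 1 carries the same difluoromethoxy and gives 1420 nM, the step is expected to be small, namely a 1.1-fold higher number from compound 2 to compound 3 (0.05 log units; within the scatter). Compound 3 is estimated to give 1000 nM, between 400 nM and 2500 nM.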

Compound 3, half-maximal inhibitory concentration: 186 nM
Beside the measured number, compound 3's estimate is 5.4-fold (0.73 log units) above it, outside the stated range (below it).
By their numbers in this assay, from the lowest: compound 3; then compounds 2 and 1 (each within the scatter of the next).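

In this assay, for the compounds shown here, difluoromethoxy in place of methoxy gives a 4.8-fold lower number from compound 2 to compound 3 (0.68 log units; beyond the scatter) on the shared core, the first measured reading of this change at this oxygen. With the difluoromethoxy held, 3,4-dimethoxypyridin-2-yl in place of 4-methoxy-3,5-dimethylpyridin-2-yl gives a 7.6-fold lower number from compound 1 to compound 3 (0.88 log units; beyond the scatter), so difluoromethoxy alone does not bring the low number of compound 3. Nothing measured here explains either step. From the compounds shown here alone, whether the methoxy change carries over to the 4-methoxy-3,5-dimethylpyridin-2-yl side remains open. So does what trifluoromethoxy or ethoxy would give on this aromatic ring.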